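The source may report more compounds than this note shows. Statements on the series, on what has been measured and on what is new or still open speak of the compounds shown alone.

Compound 1 is `Nc1nc(OCC(F)(F)F)c2ncn(/C=C3/CC3(CO)CO)c2n1`. In an ADME assay on Akata cells (Homo sapiens) for cytotoxicity, with a stated time of 7 days (a lower number here means that less compound is tolerated, a higher number that more compound is tolerated), compound 1 gives > 20000 nM, which is a limit of the assay and not a number. Compound 2 is `COCCOc1nc(N)nc2c1ncn2/C=C1/CC1(CO)CO`. In this assay compound 2 gives > 20000 nM, again only a limit.

Compound 2 therefore stands at the limit of this assay, as the limit of > 20000 nM in this assay, at which 2 of the 2 values shown sit, shows. The step that the two limits leave unreadable from compound 1 to compound 2 has both of its ends at a limit and cannot be sized. Compound 3, `CCCSc1nc(N)nc2c1ncn2/C=C1/CC1(CO)CO`, differs from compound 2 in one place: propylsulfanyl in place of 2-methoxyethoxy on an aromatic carbon. Among the measured compounds shown here, the only measured step concerns another part of the shared core and is itself unreadable, so nothing measured gives a size for the step from compound 2 to compound 3. With both values shown sitting at the limit, compound 3 is expected to stay there as well, the estimated step that the limit leaves unreadable from compound 2 to compound 3 being none beyond the scatter. Compound 3 is thus estimated at 30000 nM, in the range 15000 nM to 100000 nM.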

Compound 3, half-maximal cytotoxic concentration: > 20000 nM
Compound 3 ended at the assay's limit; the forecaster's own chance of this, stated with the estimate: 75%; the middle value is on the limit's open side.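

Compound 3, like compound 1 and compound 2, gives only a limit in this assay, so no step among these three compounds can be read: the limit of > 20000 nM in this assay, at which 3 of the 3 values shown sit. The compounds shown leave open how much cytotoxicity differs among them, and whether any substituent on that aromatic carbon would give a readable value.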